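This account rests on a few compounds, and the source may have more. Where it says the series, first, only, none or still open, it means among the compounds named here.

Compound 1 `C#CCN(C)/N=N/c1nc[nH]c1C(N)=O`: 3.61
Compound 2 `CN(Cc1ccccc1)/N=N/c1nc[nH]c1C(N)=O`: 3.43
Compound 3 `CCCN(C)/N=N/c1nc[nH]c1C(N)=O`: 3.58

Three compounds share one core and differ only in the group carried on a saturated chain carbon bound to an amine nitrogen. In a functional assay on L1210 cells (Mus musculus) for antiproliferative activity (a lower number here means a less potent compound, a higher number a more potent compound, by a factor of ten per unit of this negative logarithm), compound 3 gives 3.58, and it sits among the others rather than apart from them: a number 0.03 log units lower from compound 1 to compound 3 (within the scatter), and a number 0.15 log units higher from compound 2 to compound 3 (within the scatter). The third measured pair behaves the same way, with a number 0.18 log units lower from compound 1 to compound 2 (within the scatter).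

Compound 4 `CC(C)CN(C)/N=N/c1nc[nH]c1C(N)=O` is the next step from compound 3. The change is small: methyl in place of hydrogen on a saturated chain carbon bound to two saturated chain carbons. Within the data shown here, no measured pair makes exactly this change. The three steps that exist all swap the whole group on the chain carbon next to the nitrogen, from ethynyl to phenyl to ethyl, and each of them stays within the scatter, so adding one more carbon to that chain in compound 4 is expected to give, at most, a step of the same order in this assay, with no clear direction. The expected step is a number 0.03 log units lower from compound 3 to compound 4 (within the scatter). Compound 4 is therefore estimated at 3.55, with a likely range from 3.25 to 3.85.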

Compound 4, logarithm of the reciprocal of the active concentration, log(1/C): 3.51
Estimate against measurement, compound 4: 0.04 log units above; the range from low to high includes it.
By their numbers in this assay, from the lowest: compounds 2, 4, 3 and 1 (each within the scatter of the next).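

Read as propyl to isobutyl, the change from compound 3 adds a branch to the chain rather than replacing the whole group, and in this assay it gives a number 0.07 log units lower from compound 3 to compound 4 (within the scatter), so this one added methyl leaves no change that can be told from scatter. Compared with the other two compounds, isopropyl on the saturated chain carbon bound to an amine nitrogen gives a number 0.08 log units higher from compound 2 to compound 4 (within the scatter) and a number 0.10 log units lower from compound 1 to compound 4 (within the scatter), which places isopropyl with ethynyl, phenyl and ethyl in a single cluster of values that this assay does not separate, with none of the four compounds going against this. Nothing presented here gives a reason for how closely these numbers agree.

The groups shown at this position contain only carbon and hydrogen, so it remains open whether a hydroxyl, an amine, a carboxylic acid or a much longer chain such as octyl would move the number beyond the scatter. The methyl on the amine nitrogen is also the same in all four compounds, so replacing it with ethyl or hydrogen remains an open question as well.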